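A few compounds are considered here, and "the series" means these few. Any claim that something is new, unique, unknown or untested is made for them only; others in the source may bear on it.

Measured compounds:
- Compound 1, `CCCN1CCC(C(=O)Nc2cc(Cl)c(N)cc2OC)CC1`: > 10 mg/kg
- Compound 2, `COc1cc(N)c(Cl)cc1NC(=O)C1CCN(Cc2ccccc2F)CC1`: > 4 mg/kg

In a functional assay on the whole organism for antagonist activity, with Mus musculus as the target (a lower number here means that less compound is needed, a higher number that more compound is needed for the effect), compound 1 reaches only a limit of the assay, > 10 mg/kg. Compound 2 in this assay also gives only a limit, > 4 mg/kg. Within the data shown here, the single measured step, a step that the two limits leave unreadable from compound 1 to compound 2, therefore cannot be read in size or direction, due to the limit of > 10 mg/kg in this assay, at which 1 of the 2 values shown sits, and (the limit of > 4 mg/kg in this assay, at which 1 of the 2 values shown sits). Compound 2 thus stands at a limit, with no number to build on.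

Compound 3, `COc1cc(N)c(Cl)cc1NC(=O)C1CCN(Cc2cccc(Cl)c2)CC1`, differs from compound 2 by 3-chlorophenyl in place of 2-fluorophenyl on a saturated chain carbon bound to an amine nitrogen in a ring. Among the measured compounds shown here, no measured step touches this kind of exchange, and the one step that is available is itself unreadable, so nothing in the measured pair points to a change in either direction beyond the scatter in this assay. The expectation for compound 3 is therefore a value close to where compound 2 sits, again most likely reported as a limit. The estimate for compound 3 is 6 mg/kg, with a range from 2 mg/kg to 30 mg/kg. This estimate corresponds to an expected step that the limit leaves unreadable from compound 2 to compound 3.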

Compound 3, dose for half-maximal effect: > 4 mg/kg
Compound 3: only a limit was reported; the forecaster's own chance of this, stated with the estimate: 60%; the middle value is on the limit's open side.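

Compound 3 also gives only a limit in this assay, > 4 mg/kg. None of the steps linking compound 1, compound 2 and compound 3 can be read, in size or in direction: the limit of > 4 mg/kg in this assay, at which 2 of the 3 values shown sit.

The compounds shown leave open what dose any of the three needs, and whether 3-chlorophenyl in place of 2-fluorophenyl changes that dose at all.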